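This account rests on a few compounds, and the source may have more. Where it says the series, first, only, none or still open, it means among the compounds named here.

Of the compounds shown here, three from a single series have been measured in an assay on CHO cells for displacement of a labelled ligand from Substance-P receptor (Homo sapiens); on this read-out lower numbers stand for stronger inhibition and higher numbers for weaker inhibition. Compound 1 `C[C@@H](O[C@@H]1CN(C=O)C[C@H]1c1ccc(F)cc1)c1cc(C(F)(F)F)cc(C(F)(F)F)c1` carries a plain formyl group on the ring nitrogen and gives 0.24 nM. Compound 2 `C[C@@H](O[C@@H]1CN(C(=O)[C@@H]2CCC(=O)N2C)C[C@H]1c1ccc(F)cc1)c1cc(C(F)(F)F)cc(C(F)(F)F)c1` gives 0.12 nM in this assay, and compound 3 `CCNC(=O)N1C[C@@H](O[C@H](C)c2cc(C(F)(F)F)cc(C(F)(F)F)c2)[C@H](c2ccc(F)cc2)C1` gives 0.1 nM. Compound 2 thus sits among the three with its nearest neighbour compound 3 and its furthest neighbour compound 1, and it lies within the scatter of both of them, so no order among the three can be read from these numbers.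

Compound 4 `C[C@@H](O[C@@H]1CN(C(=O)NC(C)(C)C)C[C@H]1c1ccc(F)cc1)c1cc(C(F)(F)F)cc(C(F)(F)F)c1` is the next member to be tested. Relative to compound 2 the change is (tert-butyl)amino in place of 1-methyl-5-oxopyrrolidin-2-yl on a carbonyl carbon. The steps already seen at this carbonyl carbon were all small: a 2.0-fold lower number from compound 1 to compound 2 (0.30 log units; within the scatter), a 2.4-fold lower number from compound 1 to compound 3 (0.38 log units; beyond the scatter) and a 1.2-fold lower number from compound 2 to compound 3 (0.08 log units; within the scatter). Among the compounds with values here, the closest precedent is compound 3, whose step from compound 2 stayed within the scatter, and compound 4 is another carbamoyl variant of the same kind.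

Compound 4 is therefore expected to give a number close to that of compound 2, an expected 1.2-fold lower number from compound 2 to compound 4 (0.08 log units; within the scatter) in this assay. The estimate for compound 4 is 0.1 nM, with a range from 0.04 nM to 0.3 nM.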

Compound 4, half-maximal inhibitory concentration: 0.14 nM
Compound 4: middle estimate off by 1.4-fold (0.15 log units), on the low side, and the stated range covers the measured number.
By their numbers in this assay, from the lowest: compounds 3, 2, 4 and 1 (each within the scatter of the next, the first and the last beyond it).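

The step to compound 4 shows that in this assay this carbonyl carbon can lose the 1-methyl-5-oxopyrrolidin-2-yl, with its ring, hydrogen-bond acceptor and defined stereocentre, and take the open-chain (tert-butyl)amino, with a hydrogen-bond donor, without a change that can be read: a 1.2-fold higher number from compound 2 to compound 4 (0.07 log units; within the scatter). The urea-type pair adds a second finding, since tert-butyl in place of ethyl on the amide-type nitrogen also stays unresolved, with a 1.4-fold higher number from compound 3 to compound 4 (0.15 log units; within the scatter), and although a 2.4-fold lower number from compound 1 to compound 3 (0.38 log units; beyond the scatter) lay beyond the scatter, a 1.7-fold lower number from compound 1 to compound 4 (0.23 log units; within the scatter) does not, so the gain seen for compound 3 over the formyl compound 1 is not repeated by this second carbamoyl group. No measurement is available that bears on why these different groups give such similar numbers.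

As far as these compounds go, it remains open whether a carboxylic acid or an amine carried on this carbonyl carbon would move the number beyond the scatter of compound 2. From the compounds shown here alone, it is equally open whether a longer chain or a phenyl ring on the amide-type nitrogen would keep the number in the same narrow span.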